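This account rests on a few compounds, and the source may have more. Where it says the series, first, only, none or still open, it means among the compounds named here.

Compound 1 `COc1ccc(-n2ccc(=O)c(C(=O)Nc3ccc(Oc4ccnc5c4ccn5C)cc3)n2)cc1` in a functional assay on A549 cells (Homo sapiens) for cytotoxicity, read by MTT assay, with a stated time of 72 h (a lower number here means a stronger inhibitor, a higher number a weaker inhibitor), gives only a limit of the assay, > 60000 nM. Compound 2 `Cn1ccc2c(Oc3ccc(NC(=O)c4nn(-c5ccc(Cl)c(F)c5)ccc4=O)cc3)ccnc21` likewise gives only a limit, > 60000 nM.

Compound 2 therefore stands at the limit, with no numerical value, as does the one other compound shown (the limit of > 60000 nM in this assay, at which 2 of the 2 values shown sit). Compound 3 `Cn1ccc2c(Oc3ccc(NC(=O)c4nn(-c5ccc(Cl)c(C(F)(F)F)c5)ccc4=O)cc3)ccnc21` differs from compound 2 by trifluoromethyl in place of fluoro on an aromatic carbon. Going by the values given here, the only measured step, a step that the two limits leave unreadable from compound 1 to compound 2, is unreadable, so no size of step can be taken from it. The expected step from compound 2 to compound 3 is a step that the limit leaves unreadable from compound 2 to compound 3, with the strong likelihood that compound 3 again gives only a limit. Compound 3 is estimated at 80000 nM, between 20000 nM and 300000 nM.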

Compound 3, half-maximal inhibitory concentration: 11400 nM
For compound 3 the middle estimate is 7.0-fold (0.85 log units) above the measured one; measured number outside the range, below it.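

In this assay, this position now gives a readable result: trifluoromethyl in place of fluoro gives an at least 5.2-fold lower number from compound 2 to compound 3 (0.72 log units; beyond the scatter), and 4-chloro-3-(trifluoromethyl)phenyl in place of 4-methoxyphenyl gives an at least 5.2-fold lower number from compound 1 to compound 3 (0.72 log units; beyond the scatter). Both steps start from a limit of the assay, so they give only a minimum size, and the earlier step between the two limits cannot be read. Compound 3 is the only compound shown with a numerical value: the limit of > 60000 nM in this assay, at which 2 of the 3 values shown sit.

The compounds shown leave open how other groups at this position, such as a methyl, a nitrile or an amine, would read. They also leave open whether a still lower number can be reached here.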